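The source may report more compounds than this note shows. Statements on the series, on what has been measured and on what is new or still open speak of the compounds shown alone.

Three compounds of the series carry a measured number. Compound 1 `O=C(O)CCC(=O)OCCCCCCSc1ccc([N+](=O)[O-])c2nonc12` gives 3640 nM in a functional assay on A549 cells (Homo sapiens) for inhibition, read by MTT assay, with a stated time of 72 h; a higher number here means a weaker inhibitor, a lower number a stronger inhibitor. Compound 2 `O=C(CCC(=O)OCCCCCCSc1ccc([N+](=O)[O-])c2nonc12)Nc1ccccc1F` gives 2440 nM in this assay, and compound 3 `COc1ccc(NC(=O)CCC(=O)OCCCCCCSc2ccc([N+](=O)[O-])c3nonc23)cc1` gives 6480 nM in this assay. Compound 3 thus stands highest of the three numbers; its nearest neighbour is compound 1 and its furthest is compound 2. The step of a 1.5-fold lower number from compound 1 to compound 2 (0.17 log units; within the scatter) and the step of a 1.8-fold higher number from compound 1 to compound 3 (0.25 log units; within the scatter) both put an arylamino group, (2-fluorophenyl)amino or (4-methoxyphenyl)amino, in place of hydroxy on a carbonyl carbon, while the step of a 2.7-fold higher number from compound 2 to compound 3 (0.42 log units; beyond the scatter) swaps one aryl group for the other on the amide-type nitrogen.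

Compound 4 `CN(C)CCNC(=O)CCC(=O)OCCCCCCSc1ccc([N+](=O)[O-])c2nonc12` is not yet measured. Relative to compound 3 the change is 2-(dimethylamino)ethyl in place of 4-methoxyphenyl on an amide-type nitrogen. The step of a 2.7-fold higher number from compound 2 to compound 3 (0.42 log units; beyond the scatter) bears most directly on it: that step too alters the group on the amide-type nitrogen. The steps of a 1.5-fold lower number from compound 1 to compound 2 (0.17 log units; within the scatter) and a 1.8-fold higher number from compound 1 to compound 3 (0.25 log units; within the scatter) show how far the amide substituent moves the number at all. None of these exchanges an aryl group for a chain, so the guidance is loose. A modest lower number from compound 3 to compound 4 is expected, a 1.4-fold lower number from compound 3 to compound 4 (0.16 log units; within the scatter), within or just beyond the scatter. Compound 4 is therefore estimated at 4500 nM in this assay, with a range from 1800 nM to 11000 nM.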

Compound 4, half-maximal inhibitory concentration: 5550 nM
Estimate against measurement, compound 4: 1.2-fold (0.09 log units) below; measured number inside the range.
By their numbers in this assay, from the lowest: compounds 2, 1, 4 and 3 (each within the scatter of the next, the first and the last beyond it).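

On the amide-type nitrogen, 2-(dimethylamino)ethyl, which has no ring, takes the place of 4-methoxyphenyl with no separation beyond the scatter in this assay (a 1.2-fold lower number from compound 3 to compound 4 (0.07 log units; within the scatter)), and the same holds when (2-(dimethylamino)ethyl)amino replaces hydroxy on the carbonyl carbon (a 1.5-fold higher number from compound 1 to compound 4 (0.18 log units; within the scatter)). Among the compounds shown here, compound 2 now stands apart beyond the scatter from both amides, the one with a chain (a 2.3-fold higher number from compound 2 to compound 4 (0.36 log units; beyond the scatter)) and the one with an aryl group (a 2.7-fold higher number from compound 2 to compound 3 (0.42 log units; beyond the scatter)), so this separation does not follow the line between aryl group and chain, though compound 1 goes against any clean split, lying within the scatter of compound 2 (a 1.5-fold lower number from compound 1 to compound 2 (0.17 log units; within the scatter)) as well as of compound 4. No measurement on hand accounts for these steps.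

Open, going by these compounds, is whether a plain phenyl on the amide-type nitrogen would fall with compound 2 or with compound 3, and whether a longer chain ending in a dimethylamino group, or a morpholine in its place, would stay within the scatter of compound 4. Also open, on these data alone, is whether these steps would hold on any cell line other than the one used here.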